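The source may hold more compounds than are shown below. What is called first, only, known or untested is meant among the compounds shown, and "the series" means these compounds.

The series shares one core; compound 1 `CCC(Oc1cccc(CCCn2cc(C(c3ccccc3)c3ccccc3)ccc2=O)c1)C(=O)O` carries a 1-carboxypropyl group on the aromatic oxygen, and in an assay on HEK293 cells for displacement of a labelled ligand from chemoattractant receptor-homologous molecule expressed on Th2 cells (Cavia porcellus), read by scintillation counting, with a stated time of 2 h (on this read-out lower numbers stand for stronger inhibition and higher numbers for weaker inhibition), compound 1 gives 990 nM. Compound 2 `CC(C)(Oc1cccc(CCCn2cc(C(c3ccccc3)c3ccccc3)ccc2=O)c1)C(=O)O` carries a 1-carboxy-1-methylethyl group in that place. In this assay compound 2 reaches only the assay limit of > 1000 nM, so no number is known for it. Among the compounds with values here, the single measured step, a number no lower from compound 1 to compound 2 (the limit leaves the size open), cannot be sized because of the limit of > 1000 nM in this assay, at which 1 of the 2 values shown sits. Compound 3 `O=C(O)CCCOc1cccc(CCCn2cc(C(c3ccccc3)c3ccccc3)ccc2=O)c1` differs from compound 2 by 3-carboxypropyl in place of 1-carboxy-1-methylethyl on an oxygen on an aromatic ring. Within the data shown here, no measured step covers this rearrangement directly; the one step available shows only that the value did not fall from compound 1 to compound 2. Among the measured compounds shown here, compound 1 at 990 nM is the only number nearby. Compound 3 is therefore expected to sit in that region, the step of an at least 1.1-fold lower number from compound 2 to compound 3 (0.04 log units; that floor lies within the scatter) being uncertain in direction. The estimate for compound 3 is 900 nM, within the range 200 nM to 5000 nM.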

Compound 3, half-maximal inhibitory concentration: 99 nM
Beside the measured number, compound 3's estimate is 9.1-fold (0.96 log units) above it; measured number outside the range, below it.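

The position on the oxygen on the aromatic ring responds clearly to how the acid-bearing chain is arranged, which compounds 1 and 2 alone could not show. In this assay, 3-carboxypropyl in this place gives a 10-fold lower number from compound 1 to compound 3 (1.00 log units; beyond the scatter), and against 1-carboxy-1-methylethyl, which has the same atoms joined differently, it gives an at least 10-fold lower number from compound 2 to compound 3 (1.00 log units; beyond the scatter). The second step has only a floor and no exact size because compound 2 carries a limit and not a number: the limit of > 1000 nM in this assay, at which 1 of the 3 values shown sits.

The compounds shown leave open whether a longer chain than 3-carboxypropyl, or a shorter one such as 2-carboxyethyl, would give a lower number still. They also leave open whether the carboxylic acid itself is required at the end of this chain, or whether an amide or a tetrazole could stand in its place.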